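This account rests on a few compounds, and the source may have more. Where it says the series, first, only, none or still open, it means among the compounds named here.

In a functional assay on T29Kt1 cells (Homo sapiens) for cytotoxicity, read by sulforhodamine B assay, with a stated time of 3 days (on this read-out lower numbers stand for stronger inhibition and higher numbers for weaker inhibition), compound 1 `OCc1cn(Cc2ccc(Cl)cc2)c2ccccc12` gives 79 nM, compound 2 `Cc1ccc(Cn2cc(CO)c3ccccc32)cc1` gives 150 nM, and compound 3 `OCc1cn(Cc2ccc(Cl)cc2)c2ccc(F)cc12` gives 80 nM. These three numbers all lie within the usual scatter of one another, so compound 3 cannot be told apart from either of the other two. Compound 4 `Cc1ccc(Cn2cc(CO)c3cc(F)ccc32)cc1` differs from compound 3 in one place: methyl in place of chloro on an aromatic carbon, para to a large group. Among the measured compounds shown here, two measured steps bear on this change. The same replacement, on the core without the fluoro group, gave a 1.9-fold higher number from compound 1 to compound 2 (0.28 log units; within the scatter). Fluoro in place of hydrogen on an aromatic carbon gave a 1.0-fold higher number from compound 1 to compound 3 (0.01 log units; within the scatter), so the earlier replacement may well carry over to the fluoro series. A modest rise is therefore expected, in the same direction and not beyond the scatter. The expected step is a 1.9-fold higher number from compound 3 to compound 4 (0.27 log units; within the scatter). Compound 4 is estimated at 150 nM, with an expected range from 80 nM to 280 nM.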

Compound 4, half-maximal inhibitory concentration: 30 nM
Compound 4: middle estimate off by 5.0-fold (0.70 log units), on the high side; measured number below the stated range.
By their numbers in this assay, from the lowest: compound 4; then compounds 1, 3 and 2 (each within the scatter of the next).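

With the fluoro group on the core, methyl in place of chloro gives a 2.7-fold lower number from compound 3 to compound 4 (0.43 log units; beyond the scatter), so this position responds differently on the two cores: the same change on two cores in this assay, a 1.9-fold higher number (0.28 log units; within the scatter) from compound 1 to compound 2 and a 2.7-fold lower number (0.43 log units; beyond the scatter) from compound 3 to compound 4, 5.1-fold (0.70 log units) apart, beyond the scatter of two such steps. Fluoro in place of hydrogen also depends on its partner, giving a 5.0-fold lower number from compound 2 to compound 4 (0.70 log units; beyond the scatter) when methyl is present, unlike its step when chloro is present: the same change on two cores in this assay, a 1.0-fold higher number (0.01 log units; within the scatter) from compound 1 to compound 3 and a 5.0-fold lower number (0.70 log units; beyond the scatter) from compound 2 to compound 4, 5.1-fold (0.70 log units) apart, beyond the scatter of two such steps. Across these four compounds, then, the two changes do not simply add up, and the effect of each can be read only alongside the other.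

The compounds leave open whether this pairing with fluoro extends to other groups at this position, such as ethyl, methoxy or bromo. They also do not tell why the two changes act together.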